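The compounds below may be only part of what the source reports. "The series", "measured", "known", "first", "only" and "open" are said of these compounds alone.

Measured compounds and their values:
- compound 1, `Cc1ccccc1OCC(=O)Nc1ccc(OCC(=O)O)c(F)c1`: 20.8%
- compound 2, `Cc1cccc(OCC(=O)Nc2ccc(OCC(=O)O)c(F)c2)c1`: 45.4%

For the measured compounds named here, in a functional assay on CHO cells for agonist activity at Free fatty acid receptor 1 (Homo sapiens), read by FLIPR, tested at 100 nM (a lower number here means a weaker effect, a higher number a stronger effect of the compound at the concentration tested), compound 2 gives 45.4%, the higher of the two numbers measured so far, and compound 1 gives 20.8%. Going by the values given here, the single step between them, a number 24.6 percentage points higher from compound 1 to compound 2 (beyond the scatter), shifts the methyl from one position of the phenyl ring to another and is the only measured comparison available.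

Compound 3, `CCc1ccc(OCC(=O)Nc2ccc(OCC(=O)O)c(F)c2)cc1`, has not yet been measured in this assay. Its difference from compound 2 is 4-ethylphenyl in place of 3-methylphenyl on an oxygen on a saturated carbon. Among the compounds with values here, no measured step covers an ethyl group or the 4-position of this ring; the one step seen, a number 24.6 percentage points higher from compound 1 to compound 2 (beyond the scatter), only shows that moving a small alkyl group around the phenyl ring can change the read-out by a modest amount, in either direction for all that is known. Compound 3 is therefore expected to sit near compound 2, with a step of a number 4.6 percentage points higher from compound 2 to compound 3 (within the scatter), which is within the usual scatter. The estimate for compound 3 is 50%, with a range from 25% to 75%.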

Compound 3, a percentage reported as activity, at one concentration (the size of the read-out at that concentration, not a potency): 14.6%
Beside the measured number, compound 3's estimate is 35.4 percentage points above it; measured number below the stated range.
By their numbers in this assay, from the lowest: compounds 3 and 1 (each within the scatter of the next); then compound 2.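

In this assay, for the compounds shown here, the change to 4-ethylphenyl on an oxygen on a saturated carbon does not keep the read-out of compound 2 but brings a number 30.8 percentage points lower from compound 2 to compound 3 (beyond the scatter), so a change at this place can also go sharply downward, where the only earlier step went upward. Against the 2-methylphenyl group, the same 4-ethylphenyl group gives a number 6.2 percentage points lower from compound 1 to compound 3 (within the scatter) and these two compounds cannot be ordered, which leaves compound 2, with its 3-methylphenyl group, as the only one of the three beyond the scatter of both others. Nothing available here explains why these groups differ in this way.

The change from compound 2 to compound 3 alters both the place of the alkyl group on the phenyl ring and the length of that group, so the compounds shown cannot separate the two contributions to the drop. Going by these compounds, a 3-ethylphenyl or a 4-methylphenyl group would pull these two changes apart, and how a longer chain such as 3-propylphenyl, or an amine on the phenyl ring, would fare at this place also remains open.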